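Swapping a Sulfanyl Group for a Cyclohexyloxy Group

The source may report more compounds than this note shows. Statements on the series, on what has been measured and on what is new or still open speak of the compounds shown alone.

Compound 2 `Cc1cc(SC(C)(C)C)c(S(C)(=O)=O)cc1C(=O)N=C(N)N` stands at the highest of the two numbers measured in a functional assay for inhibition of sodium/hydrogen exchanger (Oryctolagus cuniculus) (on this read-out higher numbers stand for weaker inhibition and lower numbers for stronger inhibition), giving 22 nM; its nearest neighbour is compound 1 `Cc1cc(C)c(S(C)(=O)=O)cc1C(=O)N=C(N)N`, which gives 11 nM. Within the data shown here, the only measured step, a 2.0-fold higher number from compound 1 to compound 2 (0.30 log units; within the scatter), put (tert-butyl)sulfanyl in place of methyl on an aromatic carbon and left the reading within the usual scatter. Compound 3 `Cc1cc(OC2CCCCC2)c(S(C)(=O)=O)cc1C(=O)N=C(N)N` has not yet been measured; it differs from compound 2 in this way: cyclohexyloxy in place of (tert-butyl)sulfanyl on an aromatic carbon. That single step is the one that bears on the change here, and it was small, so the exchange of one group for another at the same aromatic carbon is expected to move the number little, if at all, beyond the scatter. Compound 3 is therefore estimated at 30 nM, with a range from 10 nM to 100 nM, which means an expected step of a 1.4-fold higher number from compound 2 to compound 3 (0.13 log units; within the scatter).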

Compound 3, half-maximal inhibitory concentration: 37 nM
The estimate for compound 3 lay 1.2-fold (0.09 log units) below the measured number; low and high end bracket the measured number.
By their numbers in this assay, from the lowest: compounds 1, 2 and 3 (each within the scatter of the next, the first and the last beyond it).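

In this assay the exchange of (tert-butyl)sulfanyl for cyclohexyloxy gives a 1.7-fold higher number from compound 2 to compound 3 (0.23 log units; within the scatter) and so does not tell these two groups apart at this aromatic carbon. Set against the methyl group of compound 1, cyclohexyloxy gives a 3.4-fold higher number from compound 1 to compound 3 (0.53 log units; beyond the scatter) as the first step at this position to pass the scatter, so replacing methyl here can weaken inhibition measurably, though only modestly. Nothing available explains either step.

The compounds shown cannot separate the oxygen link from the ring, which a methoxy group or a cyclohexylsulfanyl group at the same carbon would help to do. They also leave open how this position would respond to an amine or a carboxylic acid, since every group shown here carries no net charge.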